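The compounds below may be only part of what the source reports. "The series", "measured", "known", "first", "only" and "open" are said of these compounds alone.

Compound 1, `COC(=O)N[C@@H](CSC)C(=O)N1CCC[C@H]1c1ncc(-c2ccc(-c3ccc(-c4cnc([C@@H]5CCCN5C(=O)[C@@H](NC(=O)OC)C(C)C)[nH]4)cc3)cc2)[nH]1`, gives 31000 nM in an ADME assay on PBMC cells (Homo sapiens) for cytotoxicity; on this read-out lower numbers stand for higher toxicity in this test and higher numbers for lower toxicity in this test. Compound 2, `COC(=O)N[C@@H](CSC(C)(C)C)C(=O)N1CCC[C@H]1c1ncc(-c2ccc(-c3ccc(-c4cnc([C@@H]5CCCN5C(=O)[C@@H](NC(=O)OC)C(C)C)[nH]4)cc3)cc2)[nH]1`, gives 18000 nM in this assay. Compound 3, `COC(=O)N[C@@H](CCSC)C(=O)N1CCC[C@H]1c1ncc(-c2ccc(-c3ccc(-c4cnc([C@@H]5CCCN5C(=O)[C@@H](NC(=O)OC)C(C)C)[nH]4)cc3)cc2)[nH]1`, gives 41000 nM in this assay.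

Among the three measured numbers, compound 3 has the highest. Its nearest neighbour is compound 1, with a 1.3-fold higher number from compound 1 to compound 3 (0.12 log units; within the scatter), and its furthest is compound 2, with a 2.3-fold higher number from compound 2 to compound 3 (0.36 log units; beyond the scatter).

Compound 4, `COC(=O)N[C@@H](C[S+]([O-])Cc1ccccc1)C(=O)N1CCC[C@H]1c1ncc(-c2ccc(-c3ccc(-c4cnc([C@@H]5CCCN5C(=O)[C@@H](NC(=O)OC)C(C)C)[nH]4)cc3)cc2)[nH]1`, departs from compound 3 by one change: a group of 9 heavy atoms (7 carbon, 1 oxygen, 1 sulfur; one six-membered aromatic ring of carbon only) in place of a group of 3 heavy atoms (2 carbon, 1 sulfur; no ring), on a saturated chain carbon, two bonds along the chain from an amide-type nitrogen and a carbonyl carbon. All three measured steps alter the same place, so all three bear on this change. They were a 1.7-fold lower number from compound 1 to compound 2 (0.24 log units; within the scatter), a 1.3-fold higher number from compound 1 to compound 3 (0.12 log units; within the scatter) and a 2.3-fold higher number from compound 2 to compound 3 (0.36 log units; beyond the scatter). Every one of these exchanges of the sulfur-bearing side chain moved the number in this assay only a little, at most modestly, and the largest of them ran toward compound 3 as the highest. The group entering in compound 4 is larger than anything tried so far, so the measured steps give only a rough guide; on their showing, a step of the same small order is expected, if anything toward a lower number, as a 1.5-fold lower number from compound 3 to compound 4 (0.17 log units; within the scatter). Compound 4 is therefore expected to give about 28000 nM in this assay, with a likely range from 11000 nM to 70000 nM.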

Compound 4, half-maximal cytotoxic concentration: 42000 nM
Beside the measured number, compound 4's estimate is 1.5-fold (0.18 log units) below it; measured number inside the range.
By their numbers in this assay, from the lowest: compounds 2, 1, 3 and 4 (each within the scatter of the next, the first and the last beyond it).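

In this assay, the group of 9 heavy atoms with its six-membered aromatic ring, the largest yet at this saturated chain carbon, leaves the number where the small groups had it: a 1.0-fold higher number from compound 3 to compound 4 (0.01 log units; within the scatter) and a 1.4-fold higher number from compound 1 to compound 4 (0.13 log units; within the scatter) both stay within the scatter. Against compound 2, a 2.3-fold higher number from compound 2 to compound 4 (0.37 log units; beyond the scatter) is modest and about the size of a 2.3-fold higher number from compound 2 to compound 3 (0.36 log units; beyond the scatter), so compound 2 stands apart from the other three compounds, and across these four compounds the number does not follow the count of heavy atoms in the group, since the (tert-butyl)sulfanyl group in compound 2 goes with the lowest number and the group of 9 does not. Nothing available here accounts for these numbers.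

From the compounds shown here alone, it remains open whether a plain benzylsulfanyl group, with the same ring but without the oxygen, would behave as the group in compound 4 does in this assay. Going by these compounds, it is equally open whether an amine or a carboxylic acid at the end of this side chain would keep the number in the same range.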